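Swapping ethyl for phenyl on a nitrogen of the core

This account rests on a few compounds, and the source may have more. Where it says the series, first, only, none or still open, it means among the compounds named here.

Compound 1, `CCn1ncc(OCc2nnc(-c3ccccc3)o2)c(Cl)c1=O`, in a functional assay on the whole organism for inhibition, with Mythimna separata as the target, with a stated time of 5 days; on this read-out lower numbers stand for an effect already at smaller amounts and higher numbers for an effect only at larger amounts of compound: > 299000 nM, a limit of the assay.
Compound 2, `CCn1ncc(OCc2nnc(-c3ccc(F)cc3)o2)c(Cl)c1=O`, in this assay: > 299000 nM, a limit of the assay.

Compound 1 thus stands only at a limit, not at a number. The step that the two limits leave unreadable from compound 1 to compound 2 is unreadable, since (the limit of > 299000 nM in this assay, at which 2 of the 2 values shown sit). Compound 3, `O=c1c(Cl)c(OCc2nnc(-c3ccccc3)o2)cnn1-c1ccccc1`, differs from compound 1 by phenyl in place of ethyl on an aromatic nitrogen. For the measured compounds named here, no measured step covers this change, so its size and direction stay unknown, and the step that the limit leaves unreadable from compound 1 to compound 3 is an expectation only. Compound 3 is expected at 400000 nM, ranging from 30000 nM to 3000000 nM, most likely again reported as a limit.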

Compound 3, half-maximal effective concentration: 91400 nM
For compound 3 the middle estimate is 4.4-fold (0.64 log units) above the measured one, and the stated range covers the measured number.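

For the compounds shown here, on the aromatic nitrogen of the core, phenyl in place of ethyl gives the first real number in this assay, with an at least 3.2-fold lower number from compound 1 to compound 3 (0.51 log units; beyond the scatter). A lower number here means an effect at smaller amounts, so this position does respond to the group it carries, while the earlier fluoro step cannot be read. The true size of the new step stays unknown because compound 1 sits at a limit: the limit of > 299000 nM in this assay, at which 2 of the 3 values shown sit.

Which other groups on this nitrogen would do the same stays open, for instance benzyl or a longer chain such as butyl. As far as these compounds go, whether fluoro has any effect once phenyl sits on this nitrogen is also open.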